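Compound 1 to compound 4: replacing the (butylcarbonyl)oxy group

The source may hold more compounds than are shown below. What is called first, only, known or untested is meant among the compounds shown, and "the series" means these compounds.

In a functional assay on A-375 cells (Homo sapiens) for cytotoxicity, read by MTT assay (a higher number here means a weaker inhibitor, a lower number a stronger inhibitor), compound 1 `CCCCC(=O)Oc1cc(/C=C/C(=O)c2ccc(OC)c3c2OC(C)(C)C=C3)ccc1OC` gives 220 nM, level within the scatter with compound 2 `COc1ccc(/C=C/C(=O)c2ccc(OC)c3c2OC(C)(C)C=C3)cc1OC(=O)C(C)C` at 310 nM. Both stand clearly under compound 3 `COc1ccc(/C=C/C(=O)Oc2cc(/C=C/C(=O)c3ccc(OC)c4c3OC(C)(C)C=C4)ccc2OC)cc1` at 2630 nM. Changing the group on the carbonyl carbon gave a 1.4-fold higher number from compound 1 to compound 2 (0.15 log units; within the scatter) and a 12-fold higher number from compound 1 to compound 3 (1.08 log units; beyond the scatter). Compound 4 `COc1ccc(/C=C/C(=O)c2ccc(OC)c3c2OC(C)(C)C=C3)cc1CS(C)(=O)=O` removes that whole group from the aromatic carbon, with (methylsulfonyl)methyl entering: (methylsulfonyl)methyl in place of (butylcarbonyl)oxy on an aromatic carbon. Within the data shown here, no measured step makes this kind of change, so those steps bear on it only indirectly. Among the measured compounds shown here, with a 12-fold higher number from compound 1 to compound 3 (1.08 log units; beyond the scatter) as the only large step and pointing upward, a rise in the number is expected, though with wide uncertainty. The estimated step is a 2.7-fold higher number from compound 1 to compound 4 (0.44 log units; beyond the scatter). For compound 4 the estimated value is 600 nM, with an expected range of 200 nM to 2000 nM.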

Compound 4, half-maximal inhibitory concentration: > 10000 nM
Compound 4 gave a limit, no number (the forecaster's own chance of this, stated with the estimate: 3%); middle value at least 16-fold (1.22 log units) from the limit.
By their numbers in this assay, from the lowest: compounds 1 and 2 (each within the scatter of the next); then compound 3. At a limit, above all of these: compound 4.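

In this assay compound 4 gives only a limit, not a number: the limit of > 10000 nM in this assay, at which 1 of the 4 values shown sits.

Earlier changes on the carbonyl carbon left the (butylcarbonyl)oxy linkage in place, whereas exchanging the whole group on this aromatic carbon gives an at least 45-fold higher number from compound 1 to compound 4 (1.65 log units; beyond the scatter) and an at least 32-fold higher number from compound 2 to compound 4 (1.50 log units; beyond the scatter). The leaving and entering groups show the same hydrogen-bond donor and acceptor counts and neither holds a ring, so these counts do not separate them.

On these data alone, the true size of the loss remains open past the limit. Also open, as far as these compounds go, is whether an amine or a hydroxyl group on this aromatic carbon would keep the activity of compound 1.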